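The compounds below may be only part of what the source reports. "The series", "measured", "known", "first", "only" and "open" are said of these compounds alone.

Working notes on the series.

Compound 1 `CCNC(=O)c1ccc(Oc2cc(Cl)cc(CC(=O)O)c2)c(NS(=O)(=O)c2ccc(Cl)cc2Cl)c1` is the reference point. For the measured compounds named here, in an assay on HEK293 cells for displacement of a labelled ligand from prostaglandin D2 receptor 2 (Homo sapiens), read by scintillation counting, in the presence of a further agent that is not named here (a lower number here means a stronger inhibitor, a higher number a weaker inhibitor), compound 1 gives 12 nM, the second highest of the three numbers measured so far. Compound 2 `CCNC(=O)c1ccc(Oc2cc(Cl)cc(CC(=O)O)c2)c(NS(=O)(=O)c2ccc(C)c(Cl)c2)c1` gives 4 nM, and the step of a 3.0-fold lower number from compound 1 to compound 2 (0.48 log units; beyond the scatter) is modest but beyond the scatter. Compound 3 `CCNC(=O)c1ccc(Oc2cc(Cl)cc(CC(=O)O)c2)c(NS(=O)(=O)c2ccc(C(F)(F)F)cc2Cl)c1` gives 28 nM, with the step of a 2.3-fold higher number from compound 1 to compound 3 (0.37 log units; beyond the scatter) modest and beyond the scatter, and the step of a 7.0-fold higher number from compound 2 to compound 3 (0.85 log units; beyond the scatter) somewhat larger. All three measured steps concern the aryl group on the sulfonyl sulfur only.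

Compound 4 `CCNC(=O)c1ccc(Oc2cccc(CC(=O)O)c2)c(NS(=O)(=O)c2ccc(Cl)cc2Cl)c1` differs from compound 1 in another part of the molecule: hydrogen in place of chloro on an aromatic carbon. Going by the values given here, no measured pair in this set varies that position, so nothing here bears directly on the change. Loss of a chloro from a ring carrying the carboxymethyl group is taken, as a working assumption, to cost a little; the expected step is a 2.1-fold higher number from compound 1 to compound 4 (0.32 log units; beyond the scatter), around the size of the smaller measured steps. The estimated value for compound 4 in this assay is 25 nM, with a range from 8 nM to 80 nM.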

Compound 4, half-maximal inhibitory concentration: 16 nM
Compound 4: the middle estimate sits 1.6-fold (0.19 log units) above what was measured; the measured number falls inside the stated range.
By their numbers in this assay, from the lowest: compound 2; then compounds 1, 4 and 3 (each within the scatter of the next, the first and the last beyond it).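

In this assay, for the compounds shown here, the step of a 1.3-fold higher number from compound 1 to compound 4 (0.12 log units; within the scatter) is the first reading at this position, since all earlier steps concerned the aryl group on the sulfonyl sulfur. With 2,4-dichlorophenyl on the sulfonyl sulfur, chloro and hydrogen on this aromatic carbon cannot be told apart, so the chloro meta to the carboxymethyl group is not required for a number of this size. This rests on a single pair, and no measurement available here accounts for the result.

From the compounds shown here alone, it remains open whether hydrogen and chloro also match when 3-chloro-4-methylphenyl or 2-chloro-4-(trifluoromethyl)phenyl sits on the sulfonyl sulfur. Also open, going by these compounds, is what a fluoro, a methyl or a methoxy group would give on this same carbon.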